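The source may hold more compounds than are shown below. What is called first, only, known or untested is meant among the compounds shown, and "the series" means these compounds.

Compound 1 `CC(C)COc1ccc2c(Cl)ccnc2c1` — a functional assay on HCT-116 cells (Homo sapiens) for cytotoxicity, read by MTT assay, with a stated time of 48 h; on this read-out higher numbers stand for weaker inhibition and lower numbers for stronger inhibition: 2490 nM
Compound 2 `CN(C)CCCNc1ccnc2cc(OCc3ccc(F)cc3)ccc12` — 740 nM
Compound 3 `CC(C)Oc1ccc2c(Cl)ccnc2c1` — 2590 nM

On these numbers compound 1 stands second highest of the three: its nearest neighbour is compound 3, whose number sits within the scatter of that of compound 1, and its furthest is compound 2, whose lower number lies beyond the scatter. Compound 4 `Clc1ccnc2cc(OCc3ccccc3)ccc12` is not yet measured. It differs from compound 1 in one place: phenyl in place of isopropyl on a saturated chain carbon bound to an oxygen on an aromatic ring. Going by the values given here, only one measured step bears on this change, the one between compound 1 and compound 3, a 1.0-fold higher number from compound 1 to compound 3 (0.02 log units; within the scatter), which swapped one saturated chain for another on the oxygen and left the number unmoved. Among the compounds with values here, no measured pair isolates a phenyl entering on the saturated chain carbon bound to the oxygen; compound 2 carries a different chain and a second change as well, so its lower number cannot be assigned to either. The step of a 1.6-fold lower number from compound 1 to compound 4 (0.19 log units; within the scatter) is therefore expected to be modest, leaning toward a lower number. Compound 4 is estimated at 1600 nM, within a range from 500 nM to 5000 nM.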

Compound 4, half-maximal inhibitory concentration: 2470 nM
For compound 4 the middle estimate is 1.5-fold (0.19 log units) below the measured one, within the range that was stated.
By their numbers in this assay, from the lowest: compound 2; then compounds 4, 1 and 3 (each within the scatter of the next).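

In this assay, phenyl in place of isopropyl on the saturated chain carbon bound to the oxygen gives a 1.0-fold lower number from compound 1 to compound 4 (0.00 log units; within the scatter) and stays within the scatter. Going by these compounds alone, the earlier step, a 1.0-fold higher number from compound 1 to compound 3 (0.02 log units; within the scatter), had exchanged only one saturated group for another, whereas this one shows that a six-membered aromatic ring of carbon at this place also leaves the number within the scatter of compound 1. Why the read-out does not separate these groups has no measured support here.

The compounds shown leave open whether an amine or a carboxylic acid at this place would give a step beyond the scatter. They also leave open what an amine chain in place of the chlorine would do alone, or a fluorine on the phenyl alone, as compound 2 carries both together.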